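Adding fluoro to the 4-cyanophenyl compound

A few compounds are considered here, and "the series" means these few. Any claim that something is new, unique, unknown or untested is made for them only; others in the source may bear on it.

Values in a functional assay on CWR22R cells (Homo sapiens) for antiproliferative activity, read by propidium iodide staining, with a stated time of 96 h (on this read-out lower numbers stand for stronger inhibition and higher numbers for weaker inhibition), so far

compound 1 `CC(O)(COc1ccccc1C(F)(F)F)C(=O)Nc1ccc(S(F)(F)(F)(F)F)cc1` gives 1400 nM
compound 2 `CC(O)(COc1ccc(C#N)cc1)C(=O)Nc1ccc(S(F)(F)(F)(F)F)cc1` gives 26100 nM

Of these two compounds, compound 2 carries the higher number, at 26100 nM. Compound 3 `CC(O)(COc1ccc(C#N)c(F)c1)C(=O)Nc1ccc(S(F)(F)(F)(F)F)cc1` differs from compound 2 by fluoro in place of hydrogen on an aromatic carbon, turning 4-cyanophenyl into 4-cyano-3-fluorophenyl, with the fluoro ortho to a cyano group. Among the compounds with values here, only one measured step bears on this, a 19-fold higher number from compound 1 to compound 2 (1.27 log units; beyond the scatter), and it exchanged the whole substituted phenyl group. Within the data shown here, no measured pair isolates a fluoro in place of hydrogen on an aromatic carbon, so the large size of that step does not carry over. In this assay the expected change is no more than scatter, read as a 1.5-fold lower number from compound 2 to compound 3 (0.16 log units; within the scatter). For compound 3 the estimated value is 18000 nM, with an expected range from 6000 nM to 40000 nM.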

Compound 3, half-maximal inhibitory concentration: 24300 nM
Beside the measured number, compound 3's estimate is 1.4-fold (0.13 log units) below it; the range from low to high includes it.
By their numbers in this assay, from the lowest: compound 1; then compounds 3 and 2 (each within the scatter of the next).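

In this assay, fluoro in place of hydrogen on this aromatic carbon, ortho to a cyano group, gives a 1.1-fold lower number from compound 2 to compound 3 (0.03 log units; within the scatter), so this change on the 4-cyanophenyl group stays within the scatter. The large difference from the 2-(trifluoromethyl)phenyl group also remains, with a 17-fold higher number from compound 1 to compound 3 (1.24 log units; beyond the scatter) standing alongside the earlier 19-fold higher number from compound 1 to compound 2 (1.27 log units; beyond the scatter). The data at hand offer no explanation for any of these steps.

The compounds shown leave open whether chloro or methoxy in place of the same hydrogen would also stay within the scatter. Also open, going by these compounds, is how the number in this assay would respond if the cyano group gave way to a carboxylic acid or an amine.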